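Notes on compounds 1 to 4: propyl exchanged for cyclopropyl

This account rests on a few compounds, and the source may have more. Where it says the series, first, only, none or still open, it means among the compounds named here.

Measured so far in an assay on blood for inhibition of C-X-C chemokine receptor type 3 (Homo sapiens), with a stated time of 30 min; a lower number here means a stronger inhibitor, a higher number a weaker inhibitor:
Compound 1 `Cc1nc(C)n(CC(=O)N2CCN(c3sc(C(F)(F)F)nc3-c3cnc(OC4CCC4)nc3)C[C@H]2C)n1` gives 306 nM.
Compound 2 `CCc1ncc(-c2nc(C(F)(F)F)sc2N2CCN(C(=O)Cn3nc(C)nc3C)[C@H](C)C2)cn1` gives 567 nM.
Compound 3 `CCCc1ncc(-c2nc(C(F)(F)F)sc2N2CCN(C(=O)Cn3nc(C)nc3C)[C@H](C)C2)cn1` gives 367 nM.

Compound 3 stands second of the three numbers, with its two neighbours within the scatter: a 1.2-fold higher number from compound 1 to compound 3 (0.08 log units; within the scatter) and a 1.5-fold lower number from compound 2 to compound 3 (0.19 log units; within the scatter). Compound 4 `Cc1nc(C)n(CC(=O)N2CCN(c3sc(C(F)(F)F)nc3-c3cnc(C4CC4)nc3)C[C@H]2C)n1` differs from compound 3 by cyclopropyl in place of propyl on an aromatic carbon. Going by the values given here, no measured step exchanges an open chain for a ring of the same count, so the three steps at this aromatic carbon are the only guide: a 1.9-fold higher number from compound 1 to compound 2 (0.27 log units; within the scatter), a 1.2-fold higher number from compound 1 to compound 3 (0.08 log units; within the scatter), a 1.5-fold lower number from compound 2 to compound 3 (0.19 log units; within the scatter), every one within the scatter. A step no larger than these is therefore expected in this assay, in no preferred direction, a 1.0-fold lower number from compound 3 to compound 4 (0.02 log units; within the scatter). For compound 4 the expected value is 350 nM, estimated to lie between 150 nM and 800 nM.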

Compound 4, half-maximal inhibitory concentration: 674 nM
Compound 4: the middle estimate sits 1.9-fold (0.28 log units) below what was measured; the measured number falls inside the stated range.
By their numbers in this assay, from the lowest: compounds 1, 3, 2 and 4 (each within the scatter of the next, the first and the last beyond it).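

At this aromatic carbon, exchanging an open chain for cyclopropyl stays within the scatter against both propyl (a 1.8-fold higher number from compound 3 to compound 4 (0.26 log units; within the scatter)) and ethyl (a 1.2-fold higher number from compound 2 to compound 4 (0.08 log units; within the scatter)). Going by these compounds alone, the exchange of cyclobutyloxy for cyclopropyl (a 2.2-fold higher number from compound 1 to compound 4 (0.34 log units; beyond the scatter)) gives the only step beyond the scatter so far, and it is modest, so this position now shows a small measurable range resting on that single pair. Nothing available accounts for that step.

Open, from the compounds shown here alone, is whether cyclobutyl, or an amine such as dimethylamino, on this carbon would extend that range in either direction.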